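Methyl added to the urea phenyl of compound 2

This account rests on a few compounds, and the source may have more. Where it says the series, first, only, none or still open, it means among the compounds named here.

Of the compounds shown here, three sharing one core have been measured in a functional assay on cells (T-cell, Homo sapiens) for inhibition; a higher number here means a weaker inhibitor, a lower number a stronger inhibitor. Compound 1 `COc1ccc(-c2cnc3nc(N)nc(NCc4ccccc4)c3n2)cc1OC` gives 13000 nM. Compound 3 `Cc1ccc(-c2cnc3nc(N)nc(OC(C)C)c3n2)cc1C` gives 10000 nM. Compound 2 `COc1ccc(-c2cnc3nc(N)nc(N4CCN(C(=O)Nc5ccccc5)CC4)c3n2)cc1OC` gives 3.4 nM, the lowest number of the three; its nearest neighbour is compound 3 and its furthest is compound 1, and the gap to each lies well beyond the scatter, so compound 2 is the strongest inhibitor among them.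

Compound 4 `COc1ccc(-c2cnc3nc(N)nc(N4CCN(C(=O)Nc5ccc(C)cc5)CC4)c3n2)cc1OC` is not yet measured. It differs from compound 2 in one place: methyl in place of hydrogen on an aromatic carbon. The change carries one carbon and no ring, donor or acceptor, and it sits away from the core on the phenylcarbamoyl end of the piperazine.

Among the measured compounds shown here, no measured pair in this set carries this change, so nothing here tells its direction. Methyl in place of hydrogen on an aromatic carbon is a small change, and the expectation is a step that stays within the scatter, with a slight lean toward a weaker inhibitor. The step from compound 2 to compound 4 is estimated at a 1.3-fold higher number from compound 2 to compound 4 (0.12 log units; within the scatter). Compound 4 is expected to give about 4.5 nM, with a range of 1.5 nM to 14 nM.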

Compound 4, half-maximal inhibitory concentration: 0.8 nM
Compound 4: the middle estimate sits 5.6-fold (0.75 log units) above what was measured, and the stated range ends above it.
By their numbers in this assay, from the lowest: compound 4; then compound 2; then compounds 3 and 1 (each within the scatter of the next).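

In this assay, the methyl on the aromatic ring, para to a large group, moves the number toward a stronger inhibitor (a 4.3-fold lower number from compound 2 to compound 4 (0.63 log units; beyond the scatter)). Among the compounds shown here, this is the first one-place comparison, and it shows that the phenylcarbamoyl end of the piperazine responds to a change of a single carbon, with the (4-methylphenyl)carbamoyl group accepted here. The available data offer no explanation for this gain.

On these data alone, one step from one substituent gives no trend, so it remains open whether an ethyl, a methoxy or a chlorine at the same place would follow the methyl. As far as these compounds go, it is also open whether a methyl elsewhere on this ring would give a similar step.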